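Shortening the hydroxycarbamoyl chain: compound 2 to compound 4

The source may hold more compounds than are shown below. What is called first, only, known or untested is meant among the compounds shown, and "the series" means these compounds.

Values from a functional assay on HT-29 cells (Homo sapiens) for antiproliferative activity, read by CCK-8 assay, with a stated time of 48 h (on this read-out lower numbers stand for stronger inhibition and higher numbers for weaker inhibition), as follows
- compound 1 `O=C(CCCCCCC(=O)NCCNc1nonc1/C(=N/O)Nc1ccc(F)c(Br)c1)NO` gives 14900 nM
- compound 2 `O=C(CCCCC(=O)NCCNc1nonc1/C(=N/O)Nc1ccc(F)c(Br)c1)NO` gives > 100000 nM as a limit
- compound 3 `Nc1ccccc1NC(=O)c1ccc(C(=O)NCCNc2nonc2/C(=N/O)Nc2ccc(F)c(Br)c2)s1` gives 20300 nM

Compound 2 reads > 100000 nM as a limit of this assay and not as a number. Going by these compounds, its only place is the limit of > 100000 nM in this assay, at which 1 of the 3 values shown sits, and its true value remains unknown.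

Compound 4 `O=C(CCCC(=O)NCCNc1nonc1/C(=N/O)Nc1ccc(F)c(Br)c1)NO` follows from compound 2 by one change hydroxycarbamoyl in place of (hydroxycarbamoyl)methyl on a saturated chain carbon, three bonds along the chain from a carbonyl carbon and this again shortens the chain that carries the hydroxycarbamoyl group. The same difference, cut further out, reads 3-(hydroxycarbamoyl)propyl to 2-(hydroxycarbamoyl)ethyl.

For the measured compounds named here, the one measured step that bears on this is an at least 6.7-fold higher number from compound 1 to compound 2 (0.82 log units; beyond the scatter) and it is the same kind of shortening, with its full size left open by the limit. On that step, no recovery is expected in this assay and any change is expected toward weaker inhibition. The estimated step is a number no higher from compound 2 to compound 4 (the limit leaves the size open) on this reasoning. For compound 4 the estimated value is 100000 nM with an expected range from 35000 nM to 300000 nM and a report as a limit is the likelier outcome.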

Compound 4, half-maximal inhibitory concentration: > 100000 nM
Compound 4 ended at the assay's limit; the forecaster's own chance of this, stated with the estimate: 70%; the middle value lies on the limit itself.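

In this assay compound 4 gives > 100000 nM, which is a limit and not a number. Shortening the chain that carries the hydroxycarbamoyl group past compound 2 therefore brings no readable return of activity, and the distance from the longest chain shown stands as an at least 6.7-fold higher number from compound 1 to compound 4 (0.82 log units; beyond the scatter). The step between compound 2 and compound 4 cannot be read, and the shorter chains shown can no longer be ranked against each other in this assay: the limit of > 100000 nM in this assay, at which 2 of the 4 values shown sit.

Going by these compounds, whether compound 2 and compound 4 differ at all beyond the limit stays open. Also open, on these data alone, is whether a chain longer than that of compound 1 would lower the number, and whether a carboxylic acid in place of the hydroxycarbamoyl group would keep any activity.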